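Replacing the azido group on the shared core

The source may hold more compounds than are shown below. What is called first, only, known or untested is meant among the compounds shown, and "the series" means these compounds.

Compound 1 `[N-]=[N+]=NCc1ncnc2c1ncn2[C@@H]1O[C@H](CO)[C@@H](O)[C@H]1O` stands lowest of the three numbers in a functional assay on HL-60 cells (Homo sapiens) for inhibition, with a stated time of 72 h (on this read-out higher numbers stand for weaker inhibition and lower numbers for stronger inhibition), where compound 1 gives 1880 nM. Compound 2 `OC[C@H]1O[C@@H](n2cnc3c(Cn4ccc5ccccc54)ncnc32)[C@H](O)[C@@H]1O` gives 5700 nM and compound 3 `OC[C@H]1O[C@@H](n2cnc3c(CSCc4ccccc4)ncnc32)[C@H](O)[C@@H]1O` gives 10700 nM. Both steps away from compound 1 run upward: a 3.0-fold higher number from compound 1 to compound 2 (0.48 log units; beyond the scatter) and a 5.7-fold higher number from compound 1 to compound 3 (0.76 log units; beyond the scatter), while a 1.9-fold higher number from compound 2 to compound 3 (0.27 log units; within the scatter). Compound 4 `CC(C)N(Cc1ncnc2c1ncn2[C@@H]1O[C@H](CO)[C@@H](O)[C@H]1O)C(C)C` differs from compound 1 thus: diisopropylamino in place of azido on a saturated chain carbon bound to an aromatic carbon. The two measured steps that exchange the azido group on this saturated chain carbon bear directly on this change, and both were modest and upward, so a modest upward step is expected for compound 4 as well, about a 2.9-fold higher number from compound 1 to compound 4 (0.47 log units; beyond the scatter). Compound 4 is therefore estimated to give 5500 nM in this assay, with a range of 1800 nM to 17000 nM.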

Compound 4, half-maximal inhibitory concentration: 13000 nM
The estimate for compound 4 lay 2.4-fold (0.37 log units) below the measured number; the range from low to high includes it.
By their numbers in this assay, from the lowest: compound 1; then compounds 2, 3 and 4 (each within the scatter of the next, the first and the last beyond it).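

In this assay, a third replacement of azido on this saturated chain carbon also runs upward (a 6.9-fold higher number from compound 1 to compound 4 (0.84 log units; beyond the scatter)), and here the entering group has no ring, so among these compounds the rise does not depend on a ring in that group. Diisopropylamino stays within the scatter of benzylsulfanyl (a 1.2-fold higher number from compound 3 to compound 4 (0.08 log units; within the scatter)) but not of 1H-indol-1-yl (a 2.3-fold higher number from compound 2 to compound 4 (0.36 log units; beyond the scatter)). Nothing measured here accounts for these steps.

Going by these compounds, whether any replacement on this carbon can match azido remains open. A primary amine or a carboxylic acid in its place would test this.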